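Bromophenyl rearrangement on the anilino nitrogen: compound 4 estimate

This account rests on a few compounds, and the source may have more. Where it says the series, first, only, none or still open, it means among the compounds named here.

Measured in a functional assay on JAR cells (Homo sapiens) for inhibition, read by MTT assay, with a stated time of 72 h, tested at 10 uM; a higher number here means more inhibition at the concentration tested (going by the name of the read-out), a lower number less inhibition:
- compound 1, `CCOC(=O)C1=C(Nc2ccccc2)S/C(=C\c2ccc[nH]2)C1=O`, compound 1 gives 49.2%
- compound 2, `CCOC(=O)C1=C(Nc2ccc(OC)cc2)S/C(=C\c2ccc[nH]2)C1=O`, compound 2 gives 27.6%
- compound 3, `CCOC(=O)C1=C(Nc2ccc(Br)cc2)S/C(=C\c2ccc[nH]2)C1=O`, compound 3 gives 41.5%

Compound 3 stands second highest of the three numbers. Its nearest neighbour is compound 1: the change a number 7.7 percentage points lower from compound 1 to compound 3 (within the scatter) is within the scatter, so the two are not separated by the data. Its furthest neighbour is compound 2, from which the step of a number 13.9 percentage points higher from compound 2 to compound 3 (beyond the scatter) is a modest one beyond the scatter; the related step of a number 21.6 percentage points lower from compound 1 to compound 2 (beyond the scatter) is likewise modest and beyond the scatter.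

Compound 4, `CCOC(=O)C1=C(Nc2ccccc2Br)S/C(=C\c2ccc[nH]2)C1=O`, carries the same atoms joined differently: 2-bromophenyl in place of 4-bromophenyl on an amine nitrogen. Among the compounds with values here, no measured step bears directly on this rearrangement; the three measured steps all swap the group on one aromatic carbon, and of them only the methoxy changes move beyond the scatter, while the bromo-for-hydrogen step stays within it. Within the data shown here, with no measured precedent for moving the bromine, no step beyond the scatter is expected in this assay.

Compound 4 is therefore estimated at 40%, with a range from 24% to 56%, which means an expected step of a number 1.5 percentage points lower from compound 3 to compound 4 (within the scatter).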

Compound 4, a percentage reported as inhibition, at one concentration (the size of the read-out at that concentration, not a potency): 62.7%
The estimate for compound 4 lay 22.7 percentage points below the measured number, and the stated range ends below it.
By their numbers in this assay, from the lowest: compound 2; then compounds 3 and 1 (each within the scatter of the next); then compound 4.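

Where the bromine sits on the ring carried by the amine nitrogen matters in this assay: 2-bromophenyl in place of 4-bromophenyl gives a number 21.2 percentage points higher from compound 3 to compound 4 (beyond the scatter), a separation beyond the scatter between two groups with identical atom counts. Bromo in place of hydrogen therefore no longer reads as one change: a number 7.7 percentage points lower from compound 1 to compound 3 (within the scatter) stays within the scatter for 4-bromophenyl, whereas a number 13.5 percentage points higher from compound 1 to compound 4 (beyond the scatter) lies beyond it for 2-bromophenyl. Compound 4 is the highest of the compounds shown, with its steps to all three others beyond the scatter, including a number 35.1 percentage points higher from compound 2 to compound 4 (beyond the scatter), the only large step in the set, so a substituted phenyl can exceed the plain phenyl of compound 1 at this position.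

Still open, on these data alone, is whether this gain belongs to bromine itself or would also appear with a chloro, methyl or nitrile group in place of the bromo of 2-bromophenyl, all at a single test concentration that gives no potency. Nothing available accounts for the difference between the two bromophenyl compounds.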